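The source may report more compounds than this note shows. Statements on the series, on what has been measured and on what is new or still open speak of the compounds shown alone.

Measured compounds in an in vitro functional assay on HEK285-7 cells for antagonist activity at prostaglandin D2 receptor 2 (Homo sapiens), read by BRET and beta-arrestin recruitment; a higher number here means a weaker inhibitor, a lower number a stronger inhibitor:

- compound 1 `Nc1nc(-c2ccc(Cl)cc2)c(CC(=O)O)s1` — > 100000 nM, a limit of the assay
- compound 2 `CCC(c1ccccc1)c1nc(-c2ccc(Cl)cc2)c(CC(=O)O)s1` — > 100000 nM, a limit of the assay
- compound 3 `O=C(O)Cc1sc(NCc2ccccc2)nc1-c1ccc(Cl)cc1` — 2300 nM

Compound 2 stands at the limit of this assay, with no number behind it; the same is true of compound 1, so that the limit of > 100000 nM in this assay, at which 2 of the 3 values shown sit, holds for two of the three values shown. For the measured compounds named here, compound 3 alone gives a number, and the single measured step, an at least 43-fold lower number from compound 1 to compound 3 (1.63 log units; beyond the scatter), goes from a limit to a number and is large.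

Compound 4 `COc1ccc(C(c2ccccc2)c2nc(-c3ccc(Cl)cc3)c(CC(=O)O)s2)cc1` differs from compound 2 by 4-methoxyphenyl in place of ethyl on a saturated chain carbon bound to two aromatic carbons. Going by the values given here, none of the measured steps touches this position: the step from compound 1 to compound 3 concerns a nitrogen on the core, not the saturated chain carbon bound to two aromatic carbons, so it gives no direct guide to the size or direction of the change here. Among the compounds with values here, what is known is only that compound 2 sits at the limit, so any number for compound 4 would already be a lower number than that limit.

Within the data shown here, on this basis compound 4 is expected to give a measurable but weak value in this assay, estimated at 40000 nM (range 5000 nM to 200000 nM), which would mean the step of an at least 2.5-fold lower number from compound 2 to compound 4 (0.39 log units; beyond the scatter); the expectation rests on no measured step and remains uncertain.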

Compound 4, half-maximal inhibitory concentration: 76 nM
The estimate for compound 4 lay 530-fold (2.72 log units) above the measured number, and the stated range ends above it.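

Working notes on the series. In this assay, the saturated chain carbon bound to two aromatic carbons responds strongly to the group it carries: 4-methoxyphenyl in place of ethyl gives an at least 1300-fold lower number from compound 2 to compound 4 (3.11 log units; beyond the scatter). For the compounds shown here, the earlier step, an at least 43-fold lower number from compound 1 to compound 3 (1.63 log units; beyond the scatter), concerned a nitrogen on the core and gave no reading of this place, so this result is the first evidence that a change here can carry a compound from the limit of the assay to a low number. The true size of the new step stays unknown, since its starting point, compound 2, is a limit and not a number: the limit of > 100000 nM in this assay, at which 2 of the 4 values shown sit.

The change replaces ethyl with a whole 4-methoxyphenyl group, so the compounds shown do not separate the contribution of the added aromatic ring from that of its methoxy group. From the compounds shown here alone, how a plain phenyl, a hydroxyl on the same ring, a longer chain or an amine would read at this carbon remains open, as does whether the effect seen here would hold with a different group on the nitrogen of the core.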